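The source may report more compounds than this note shows. Statements on the series, on what has been measured and on what is new or still open speak of the compounds shown alone.

Measured so far:
- compound 1, `Cn1ccc2cc(-c3cc4nccc(-c5ccc(F)cc5)n4n3)ccc21` — 5210 nM
- compound 2, `COc1cc(-c2ccnc3cc(-c4c[nH]c5ccccc45)nn23)cc(OC)c1OC` — 195 nM

In a functional assay on HeLa cells (Homo sapiens) for inhibition, read by CCK-8 assay, with a stated time of 48 h (on this read-out higher numbers stand for weaker inhibition and lower numbers for stronger inhibition), compound 2 gives 195 nM, the lower of the two numbers; compound 1 gives 5210 nM, a gap that lies well outside the scatter. Among the measured compounds shown here, the two differ in more than one place, so no step is drawn between them.

Compound 3, `COc1cc(-c2ccnc3cc(-c4cn(C)c5ccccc45)nn23)cc(OC)c1OC`, is not yet measured. Against compound 2 the change is methyl in place of hydrogen on an aromatic nitrogen.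

For the measured compounds named here, no measured step of this kind exists here. A step from compound 2 to compound 3 of a 2.1-fold higher number from compound 2 to compound 3 (0.31 log units; beyond the scatter) in this assay is expected, a small shift toward weaker inhibition, near the edge of the scatter. For compound 3 the expected value in this assay is 400 nM, within 120 nM to 1500 nM.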

Compound 3, half-maximal inhibitory concentration: 399 nM
Beside the measured number, compound 3's estimate is 1.0-fold (0.00 log units) above it; low and high end bracket the measured number.
By their numbers in this assay, from the lowest: compound 2; then compound 3; then compound 1.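

In this assay, among the compounds shown here, the change from 1H-indol-3-yl to 1-methyl-1H-indol-3-yl gives the first measured step at this aromatic nitrogen (a 2.0-fold higher number from compound 2 to compound 3 (0.31 log units; beyond the scatter)), a modest move toward weaker inhibition. The hydrogen on this nitrogen can therefore give way to methyl with only a modest change in the read-out, and inhibition is kept. This single step sets no trend for the position. Going by these compounds, whether a longer chain such as ethyl, or a chain ending in an amine or a carboxylic acid, is tolerated on this nitrogen remains open. No measurement at hand accounts for the shift.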